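Replacing the Diaminocyanopyrimidine Group on Compound 1

The source may report more compounds than this note shows. Statements on the series, on what has been measured and on what is new or still open speak of the compounds shown alone.

Measured in a functional assay on Bel-7402 cells (Homo sapiens) for inhibition, read by sulforhodamine B assay, with a stated time of 72 h; on this read-out lower numbers stand for stronger inhibition and higher numbers for weaker inhibition:
- compound 1 `C[C@H](Nc1nc(N)nc(N)c1C#N)c1nn(-c2cccc(S(C)(=O)=O)c2)c2cc(F)ccc12`: 22100 nM
- compound 2 `C[C@H](Nc1nc(N)nc(N)c1C#N)c1nn(-c2cccc(S(C)(=O)=O)c2)c2cc(Cl)ccc12`: 4460 nM
- compound 3 `C[C@H](Nc1nc(N)nc(N)c1C#N)c1nn(-c2cccnc2)c2cc(C(F)(F)F)ccc12`: 3190 nM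

Among these three, compound 1 has the highest number, at 22100 nM. Compound 4 `C[C@H](Nc1ncnc2[nH]cnc12)c1nn(-c2cccc(S(C)(=O)=O)c2)c2cc(F)ccc12` keeps the core of compound 1 and differs from it by one exchange: a group of 9 heavy atoms (5 carbon, 4 nitrogen; one five-membered aromatic ring with 2 hetero atoms, one six-membered aromatic ring with 2 hetero atoms) in place of a group of 10 heavy atoms (5 carbon, 5 nitrogen; one six-membered aromatic ring with 2 hetero atoms), on an amine nitrogen. Among the compounds with values here, the 2,6-diamino-5-cyanopyrimidin-4-yl group leaves, and no measured step covers this exchange. Within the data shown here, the only measured step, a 5.0-fold lower number from compound 1 to compound 2 (0.70 log units; beyond the scatter), is a chloro-for-fluoro change elsewhere and gives a rough scale at best. No direction follows from it, so the expected change in this assay is small, with a wide range. The expected step is a 1.4-fold lower number from compound 1 to compound 4 (0.14 log units; within the scatter). For compound 4 the estimate is 16000 nM, with an expected range from 4000 nM to 60000 nM.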

Compound 4, half-maximal inhibitory concentration: 20000 nM
Estimate against measurement, compound 4: 1.3-fold (0.10 log units) below; the measured number falls inside the stated range.
By their numbers in this assay, from the lowest: compounds 3 and 2 (each within the scatter of the next); then compounds 4 and 1 (each within the scatter of the next).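

In this assay, within the data shown here, the exchange on the amine nitrogen gives a 1.1-fold lower number from compound 1 to compound 4 (0.04 log units; within the scatter) and so, unlike the earlier steps, it tests this position directly. With the fluoro core of compound 1 held fixed, the 2,6-diamino-5-cyanopyrimidin-4-yl group and its nitrile can leave without a step beyond the scatter. No evidence is available that bears on this result. On these data alone, whether the same exchange would read alike on compound 2 stays open. So does the effect of a simple phenyl or acetyl group on this nitrogen.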